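From compound 3 to compound 4: changing the amide group

This account rests on a few compounds, and the source may have more. Where it says the series, first, only, none or still open, it means among the compounds named here.

Compound 3 (`C[C@H](NC(=O)c1ncccn1)c1ccc(NC(=O)N2CC(c3cncc(N)c3)C2)cc1`) holds the lowest number in a physicochemical assay for solubility, read by LC-MS, in phosphate buffer, with a stated time of 24 h, at pH 6.8 (a lower number here means a less soluble compound, a higher number a more soluble compound), reading 300000 nM. Compound 2 (`C[C@H](NC(=O)[C@@H]1CCCN1C)c1ccc(NC(=O)N2CC(c3ccc(N)nc3)C2)cc1`) reads 760000 nM, higher by a margin beyond the scatter. Compound 1 (`C[C@H](NC(=O)[C@@H]1CCCN1C)c1ccc(NC(=O)N2CC(c3cccnc3)C2)cc1`) gives > 1000000 nM, which is a limit and not a number.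

Compound 4 (`C[C@H](NC(=O)[C@@H]1CCCN1C)c1ccc(NC(=O)N2CC(c3cncc(N)c3)C2)cc1`) differs from compound 3 at one place: 1-methylpyrrolidin-2-yl in place of pyrimidin-2-yl on a carbonyl carbon. In short, 1-methylpyrrolidin-2-yl stands in place of pyrimidin-2-yl on a carbonyl carbon.

Among the measured compounds shown here, no measured step makes this change on its own. For the measured compounds named here, the one measured step, an at least 1.3-fold lower number from compound 1 to compound 2 (0.11 log units; that floor lies within the scatter), is amino in place of hydrogen on an aromatic carbon, and its floor lies within the scatter. On these data alone, that step stays open on one side, its starting point being (the limit of > 1000000 nM in this assay, at which 1 of the 3 values shown sits). The closest guide is compound 2 at 760000 nM, which shares the (1-methylpyrrolidin-2-yl)carbonyl group with compound 4 but differs in where the amino group sits. A rise in this assay beyond the scatter is therefore expected, bringing the number close to that of compound 2. The expected change is a 2.3-fold higher number from compound 3 to compound 4 (0.37 log units; beyond the scatter). For compound 4 the estimate is 700000 nM, with an expected range of 320000 nM to 1000000 nM.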

Compound 4, solubility: 820000 nM
Beside the measured number, compound 4's estimate is 1.2-fold (0.07 log units) below it; the range from low to high includes it.
By their numbers in this assay, from the lowest: compound 3; then compounds 2 and 4 (each within the scatter of the next). At a limit, above all of these: compound 1.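

In this assay, the carbonyl position now has its first reading from a change in one place: a 2.7-fold higher number from compound 3 to compound 4 (0.44 log units; beyond the scatter), with 1-methylpyrrolidin-2-yl in place of pyrimidin-2-yl on a carbonyl carbon. Changing 6-aminopyridin-3-yl to 5-aminopyridin-3-yl on a saturated ring carbon gives a 1.1-fold higher number from compound 2 to compound 4 (0.03 log units; within the scatter), so these two amino-bearing groups cannot be told apart in this assay. Compound 1 gives a limit and not a number, so amino in place of hydrogen on an aromatic carbon again reads only as a floor, an at least 1.2-fold lower number from compound 1 to compound 4 (0.08 log units; that floor lies within the scatter), and the size of that step stays unknown: the limit of > 1000000 nM in this assay, at which 1 of the 4 values shown sits.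

The carbonyl change rests on a single pair, so the compounds shown do not tell whether the same step would appear with 6-aminopyridin-3-yl on the saturated ring carbon. Nor do they separate the loss of pyrimidin-2-yl from the entry of 1-methylpyrrolidin-2-yl, and an open-chain amine such as dimethylaminomethyl or a carboxylic acid on the same carbonyl carbon would help to make that separation.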